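Methoxy Added to the Aryl Ether Core of Compound 1

The compounds below may be only part of what the source reports. "The series", "measured", "known", "first", "only" and "open" are said of these compounds alone.

Measured compounds:
compound 1, `Clc1ccc(COc2ccc(CNCc3ccncc3)cc2)cc1`, 4000 nM
compound 2, `COc1cc(CNCCSc2nnnn2C)ccc1OCc1ccc(Cl)nc1`, 86000 nM

Among the compounds with values here, of the two compounds measured in a functional assay on HeLa cells (Homo sapiens) for inhibition, with a stated time of 72 h (on this read-out lower numbers stand for an effect already at smaller amounts and higher numbers for an effect only at larger amounts of compound), compound 1 has the lower number; compound 2 sits well beyond the scatter from it, and no single-point step links the two, so their values are simply read side by side. Compound 3, `COc1cc(CNCc2ccncc2)ccc1OCc1ccc(Cl)cc1`, keeps the core of compound 1 and differs from it by methoxy in place of hydrogen on an aromatic carbon. Within the data shown here, no step of this kind has been measured here, so there is no gauge for its size. The expectation for this assay is a change of no more than the scatter, in either direction. Compound 3 is accordingly estimated at 4000 nM, in the range 1500 nM to 12000 nM, which means an expected step of no change at the digits printed from compound 1 to compound 3 (within the scatter).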

Compound 3, half-maximal effective concentration: 890 nM
Compound 3: the middle estimate sits 4.5-fold (0.65 log units) above what was measured, outside the stated range (below it).
By their numbers in this assay, from the lowest: compound 3; then compound 1; then compound 2.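

In this assay, within the data shown here, methoxy in place of hydrogen on an aromatic carbon gives a 4.5-fold lower number from compound 1 to compound 3 (0.65 log units; beyond the scatter) and supplies the first single-point step in this small series. Compound 2 could not show this, as it differs from compound 1 in more than one place. The step shows that this position, ortho to a group of 9 heavy atoms and meta to a group of 9 heavy atoms, tolerates a group larger than hydrogen in this read-out and that the number falls beyond the scatter, though nothing shown accounts for the shift.

The compounds shown leave open whether this step is particular to methoxy or would also appear with hydroxyl, ethoxy or fluorine on the same aromatic carbon. They also leave open whether methoxy gives a step of similar size when the pyridine-bearing amine side chain is replaced by a longer chain.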